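The source may report more compounds than this note shows. Statements on the series, on what has been measured and on what is new or still open speak of the compounds shown alone.

For the measured compounds named here, in a functional assay on Daoy cells (Homo sapiens) for antiproliferative activity, read by trypan blue exclusion and crystal violet staining, with a stated time of 72 h (a higher number here means a weaker inhibitor, a lower number a stronger inhibitor), compound 1 (`CCCCOc1ccnc2c(O)c(CNC(=O)C3CCCCC3)ccc12`) gives 510 nM, the higher of the two numbers so far, while compound 2 (`COc1ccc(C(NC(C)=O)c2cc(Cl)c3cccnc3c2O)cc1OC`) gives 210 nM, a lower number beyond the usual scatter. Compound 3 (`O=C(NCc1ccc2c(OCc3ccccc3)ccnc2c1O)C1CCCCC1`) keeps the core of compound 1 but carries phenyl in place of propyl on a saturated chain carbon bound to an oxygen on an aromatic ring. Going by the values given here, no measured pair shows this change. An estimated 1.3-fold lower number from compound 1 to compound 3 (0.11 log units; within the scatter) is expected, toward a slightly lower number and not beyond the scatter. For compound 3 the expected value is 400 nM, with an estimated range of 130 nM to 1200 nM.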

Compound 3, half-maximal inhibitory concentration: 260 nM
The estimate for compound 3 lay 1.5-fold (0.19 log units) above the measured number; the range from low to high includes it.
By their numbers in this assay, from the lowest: compounds 2, 3 and 1 (each within the scatter of the next, the first and the last beyond it).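

Phenyl in place of propyl on a saturated chain carbon bound to an oxygen on an aromatic ring is the first change at this position that can be read, and in this assay it gives a 2.0-fold lower number from compound 1 to compound 3 (0.29 log units; within the scatter) on the core of compound 1. This position therefore carries butoxy or benzyloxy without a step beyond the scatter. Nothing given here accounts for this result.

From the compounds shown here alone, whether an amine, a carboxylic acid or a longer chain at this position would give a step beyond the scatter remains open. So does the effect of a substituent on the phenyl.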